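Adding an Ethoxycarbonyl Group to a Coumarin-Lipoic Acid Conjugate

The source may report more compounds than this note shows. Statements on the series, on what has been measured and on what is new or still open speak of the compounds shown alone.

Three compounds sharing a lipoic acid amide tethered through a triazole to a coumarin ether were examined in a functional assay on PC-12 cells (Rattus norvegicus) for cytotoxicity, read by MTT assay, with stated times of 3 h and 2 h, tested at 1 uM; a lower number here means a weaker effect, a higher number a stronger effect of the compound at the concentration tested. Compound 1 `O=C(CCCCC1CCSS1)NCc1cn(CCCOc2ccc3cc(-c4ccccc4)c(=O)oc3c2)nn1` gives 31.9%. Compound 2 `O=C(CCCCC1CCSS1)NCc1cn(CCCCOc2ccc3cc(-c4ccc(Cl)c(Cl)c4)c(=O)oc3c2)nn1` gives 49.3%. Compound 3 `O=C(CCCCC1CCSS1)NCc1cn(CCCCCOc2ccc3ccc(=O)oc3c2)nn1` gives 57.2%. On these numbers compound 3 stands beyond the scatter above compound 1, while its gap to compound 2 lies within the scatter, so compound 3 and compound 2 cannot be told apart on this read-out.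

The next step keeps the five-carbon linker of compound 3 and alters only the coumarin ring. Compound 4 `CCOC(=O)c1cc2ccc(OCCCCCn3cc(CNC(=O)CCCCC4CCSS4)nn3)cc2oc1=O` differs from compound 3 in one place: ethoxycarbonyl in place of hydrogen on an aromatic carbon. Within the data shown here, no pair of measured compounds differs in that single place, so no measured step guides the expectation; the closest comparison is that compound 1 and compound 2 carry a larger aryl group at that ring position together with shorter linkers, and their values sit at or below that of compound 3.

Compound 4 is therefore expected to change little in this assay, with a step of a number 7.2 percentage points lower from compound 3 to compound 4 (within the scatter) that may be slightly downward but not clearly beyond the scatter. The estimate for compound 4 is 50%, in a range from 32% to 68%.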

Compound 4, a percentage reported as activity, at one concentration (the size of the read-out at that concentration, not a potency): 35.1%
Estimate against measurement, compound 4: 14.9 percentage points above, and the stated range covers the measured number.
By their numbers in this assay, from the lowest: compounds 1 and 4 (each within the scatter of the next); then compounds 2 and 3 (each within the scatter of the next).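

In this assay, among these compounds, putting ethoxycarbonyl in place of hydrogen on this aromatic carbon, two atoms from the ring oxygen, gives a number 22.1 percentage points lower from compound 3 to compound 4 (beyond the scatter), the first change in one place alone that can be read. The earlier compounds carried their substituents at this carbon together with different linkers, so they could not show the effect of this position alone; with the linker held constant, the read-out clearly responds to what sits on this carbon, and the scatter does not account for the step. The information at hand offers no explanation for the step, and it rests on this one pair of compounds.

Going by these compounds, it remains open whether this step belongs to the ester itself or would follow any group placed on this carbon, and a carboxylic acid, a primary amide or a single methyl group there would help to separate those readings. On these data alone, it is also open whether ethoxycarbonyl would produce a step of similar size on a compound with a shorter linker, or with the lipoic acid amide replaced by a simple alkyl amide.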